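Methoxy for methyl on the aryl ring of compound 3

A few compounds are considered here, and "the series" means these few. Any claim that something is new, unique, unknown or untested is made for them only; others in the source may bear on it.

Three members of the series have numbers in a functional assay (muscle tissue) with Cavia porcellus as the target; a lower number here means that less compound is needed, a higher number that more compound is needed for the effect. Compound 1 `COC(=O)C1=C(C)N=C(C)/C(=C(/O)OC)C1c1c(F)cccc1Cl` gives 7.59 nM. Compound 2 `COC(=O)C1=C(C)N=C(C)/C(=C(\O)OC)C1c1cccc(OC(=O)c2ccccc2)c1` gives 6310 nM. Compound 3 `COC(=O)C1=C(C)N=C(C)/C(=C(\O)OC)C1c1ccccc1C` gives 6.03 nM, the lowest of the three, though its gap to compound 1 lies within the scatter; only compound 2 stands far away, beyond the scatter.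

Compound 4 `COC(=O)C1=C(C)N=C(C)/C(=C(\O)OC)C1c1ccccc1OC` carries a single change against compound 3: methoxy in place of methyl on an aromatic carbon. Among the measured compounds shown here, no measured pair in the set shows this exchange, so its effect rests on expectation alone. A modest step toward a higher number is expected, a 3.3-fold higher number from compound 3 to compound 4 (0.52 log units; beyond the scatter), close to the edge of the scatter. For compound 4 the estimate in this assay is 20 nM, with a range from 5 nM to 80 nM.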

Compound 4, half-maximal effective concentration: 57.5 nM
Compound 4: middle estimate off by 2.9-fold (0.46 log units), on the low side; the measured number falls inside the stated range.
By their numbers in this assay, from the lowest: compounds 3 and 1 (each within the scatter of the next); then compound 4; then compound 2.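

In this assay, among the compounds shown here, methoxy in place of methyl on an aromatic carbon, ortho to a large group, gives a 9.5-fold higher number from compound 3 to compound 4 (0.98 log units; beyond the scatter), the first single-place comparison. This position therefore responds to the exchange, and the step lies beyond the usual scatter. No measurement shown bears on the reason for the rise.

Going by these compounds, whether ethoxy, a longer chain or an amine at this place would move the number further remains open. Also open, on these data alone, is whether the same exchange gives a similar step on other aryl patterns, such as that of compound 1.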